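The source may report more compounds than this note shows. Statements on the series, on what has been measured and on what is new or still open speak of the compounds shown alone.

Measured compounds in a toxicity assay on HT-29 cells (Homo sapiens) for cytotoxicity; a lower number here means that less compound is tolerated, a higher number that more compound is tolerated:
compound 1, `CN1C(=S)[C@@H](NC(=O)c2nc(Cc3ccccc3)n(CCCCC#N)n2)COc2ccccc21`, gives > 100000 nM.
compound 2, `CN1C(=S)[C@@H](NC(=O)c2nc(Cc3ccccc3)n(C3CCCCC3)n2)COc2ccccc21`, gives > 100000 nM.
compound 3, `CN1C(=S)[C@@H](NC(=O)c2nc(Cc3ccccc3)n(C3CCCCCC3)n2)COc2ccccc21`, gives > 100000 nM.

Each of these three values is a limit of the assay and not a number: the limit of > 100000 nM in this assay, at which 3 of the 3 values shown sit. Compound 3 therefore stands at the limit. The other two values shown are limits as well, so no order among compounds 1, 2 and 3 can be read from them. The three steps between them, a step that the two limits leave unreadable from compound 1 to compound 2, a step that the two limits leave unreadable from compound 1 to compound 3 and a step that the two limits leave unreadable from compound 2 to compound 3, are unreadable for the same reason; all that they show is that changing the group on the aromatic nitrogen left every compound at the limit.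

Compound 4, `CN1C(=S)[C@@H](NC(=O)c2nc(Cc3ccccc3)n(C3CCNCC3)n2)COc2ccccc21`, is not yet measured. It differs from compound 3 in one place: piperidin-4-yl in place of cycloheptyl on an aromatic nitrogen. The measured steps bear on it only loosely: each of the three earlier changes at this same aromatic nitrogen kept the compound at the limit, so no step beyond the scatter is expected in this assay in either direction, though its size cannot be judged from limits alone. Compound 4 is thus expected to sit at or near the limit again, a step that the limit leaves unreadable from compound 3 to compound 4, with an estimate of 150000 nM and a range from 40000 nM to 500000 nM.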

Compound 4, half-maximal cytotoxic concentration: > 100000 nM
Compound 4 gave a limit, no number; the forecaster's own chance of this, stated with the estimate: 85%; the middle value does not contradict the limit.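

In this assay compound 4 gives > 100000 nM as a limit and not a number. Among the compounds shown here, no step from compound 1, compound 2 or compound 3 to compound 4 can be read, since all four values are the same limit: the limit of > 100000 nM in this assay, at which 4 of the 4 values shown sit. From the compounds shown here alone, the order of these four compounds in this assay stays open, as does whether the group on the aromatic nitrogen affects the result at all.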